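Two inactive precursors and an amide for a bromophenyl series

This account rests on a few compounds, and the source may have more. Where it says the series, first, only, none or still open, it means among the compounds named here.

Activity was measured in a functional assay on HL-60 cells (Homo sapiens), read by calcium flux; a lower number here means that less compound is needed, a higher number that more compound is needed for the effect. Compound 1, with the structure `COc1ccc(Cc2cc(-c3ccc(F)cc3)nn(CC(=O)Nc3ccc(Br)cc3)c2=O)cc1`, reached only the limit of this assay, > 50000 nM, and so gave no number. Compound 2, built as `Cc1cc(Cc2ccc(C(F)(F)F)cc2)c(=O)n(CC(=O)Nc2ccc(Br)cc2)n1`, likewise reached only a limit of this assay, > 50000 nM, with no number behind it. Where compound 2 stands is therefore set by the limit of > 50000 nM in this assay, at which 2 of the 2 values shown sit, so its true potency is unknown beyond that boundary. Compound 3, with the structure `Cc1cc(Cc2ccc(C(N)=O)cc2)c(=O)n(CC(=O)Nc2ccc(Br)cc2)n1`, is not yet measured and differs from compound 2 by one change: carbamoyl in place of trifluoromethyl on an aromatic carbon. For the measured compounds named here, with both measured compounds sitting at a limit, no measured step guides the size or direction of this change, and the expected step is a step that the limit leaves unreadable from compound 2 to compound 3, within the scatter. Compound 3 is thus expected to give about 60000 nM, in the range 10000 nM to 300000 nM.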

Compound 3, half-maximal effective concentration: > 50000 nM
Compound 3 gave a limit, no number; the forecaster's own chance of this, stated with the estimate: 80%; the middle value is on the limit's open side.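

Compound 2 and compound 3 each gave only a limit in this assay, and no step can be read between them. The compounds shown leave open whether carbamoyl and trifluoromethyl differ at all, and how potent any of these compounds truly is, with all resting at one boundary: the limit of > 50000 nM in this assay, at which 3 of the 3 values shown sit.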